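Benzyl variation on the shared amide core, compound 1 to compound 3

The source may hold more compounds than are shown below. What is called first, only, known or untested is meant among the compounds shown, and "the series" means these compounds.

Two members of the series carry a measurement so far. Compound 1, `COc1ccc(CN(C(=O)CSc2nc3ccccc3s2)c2cc(OC)c(OC)c(OC)c2)cc1[N+](=O)[O-]`, and compound 2, `COc1ccc2nc(SCC(=O)N(Cc3ccc(OC)c(O)c3)c3cc(OC)c(OC)c(OC)c3)sc2c1`, share the same amide-linked core and the same trimethoxyphenyl on the amide-type nitrogen. In a functional assay on HCT-116 cells (Homo sapiens) for antiproliferative activity, read by MTT assay, with a stated time of 48 h (on this read-out lower numbers stand for stronger inhibition and higher numbers for weaker inhibition), compound 1 gives 1280 nM. In this assay compound 2 gives 352 nM. Of the two numbers, that of compound 1 is the higher, and its gap to compound 2 is beyond the scatter, so compound 1 is the weaker of the pair on this read-out. Among the compounds with values here, compound 2 differs from compound 1 in more than one place, so no single step between measured compounds is available.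

Compound 3, `COc1cc(N(Cc2ccc(Br)cc2)C(=O)CSc2nc3ccccc3s2)cc(OC)c1OC`, is not yet measured. It differs from compound 1 in one place: 4-bromophenyl in place of 4-methoxy-3-nitrophenyl on a saturated chain carbon bound to an amide-type nitrogen. Within the data shown here, with no measured step of this kind to lean on, the expectation for compound 3 is a modest move toward a lower number, but one that may well stay within the scatter. The estimated step from compound 1 to compound 3 is a 1.6-fold lower number from compound 1 to compound 3 (0.20 log units; within the scatter). For compound 3 the expected value is 800 nM, with a range from 250 nM to 2500 nM.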

Compound 3, half-maximal inhibitory concentration: 63800 nM
Beside the measured number, compound 3's estimate is 80-fold (1.90 log units) below it; measured number above the stated range.
By their numbers in this assay, from the lowest: compound 2; then compound 1; then compound 3.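

The saturated chain carbon bound to an amide-type nitrogen is now shown to be a sensitive place in this assay: 4-bromobenzyl in place of 4-methoxy-3-nitrobenzyl gives a 50-fold higher number from compound 1 to compound 3 (1.70 log units; beyond the scatter), a large step and well beyond the scatter. The earlier pair could not show this, as its two members differ in more than one place; here the core and the trimethoxyphenyl stay fixed, so the whole step belongs to this one exchange of aryl groups. Nothing measured bears on why the exchange costs so much on this read-out.

Within the data shown here, the single step cannot separate the parts of the change, as the methoxy and nitro groups leave together while the bromine enters, so it remains open whether the step follows from the loss of either group, of both, or from the bromine itself. Also open, as far as these compounds go, is how a 4-aminobenzyl group or a 4-carboxybenzyl group would read at this place, and whether a step of this size would recur on a core carrying other substituents.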